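Trimming a Biaryl to a Methyl on the Core

The source may hold more compounds than are shown below. What is called first, only, known or untested is meant among the compounds shown, and "the series" means these compounds.

Compound 1 `COc1ccc(-c2ccc3c(c2)oc(=O)n3C(=O)NCCCCc2ccccc2)cc1` is a carbamoyl benzoxazolone-type urea; in an assay on HEK293 cells for inhibition of acid ceramidase (Homo sapiens), with a stated time of 10 min (on this read-out lower numbers stand for stronger inhibition and higher numbers for weaker inhibition), compound 1 gives 67 nM. Compound 2 `O=C(NCCSCc1ccccc1)n1c(=O)oc2ccccc21` gives 65 nM and compound 3 `O=C(NCCCCc1cccs1)n1c(=O)oc2ccccc21` gives 37 nM. Compound 1 has the highest of the three numbers, yet both compound 2 and compound 3 lie within the usual scatter of it, so no order among them can be claimed. Compound 4 `Cc1ccc2c(c1)oc(=O)n2C(=O)NCCCCc1ccccc1` differs from compound 1 at one spot: methyl in place of 4-methoxyphenyl on an aromatic carbon. Because compound 2 gives 65 nM and compound 3 gives 37 nM while neither carries a substituent on the shared core at all, a small step is expected here, if any, toward a weaker number. The estimate for compound 4 is 90 nM (range 35 nM to 250 nM), an expected step of a 1.3-fold higher number from compound 1 to compound 4 (0.13 log units; within the scatter).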

Compound 4, half-maximal inhibitory concentration: 66 nM
For compound 4 the middle estimate is 1.4-fold (0.13 log units) above the measured one; measured number inside the range.
By their numbers in this assay, from the lowest: compounds 3, 2, 4 and 1 (each within the scatter of the next).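

In this assay, among these compounds, methyl in place of 4-methoxyphenyl on this aromatic carbon gives a 1.0-fold lower number from compound 1 to compound 4 (0.01 log units; within the scatter), the first direct reading at this position. The whole aromatic ring and its methoxy oxygen can therefore go, leaving a single carbon, with no change that this read-out can separate from scatter. Nothing measured here offers an explanation for this result.

Still open, on these data alone, is whether an amine or a carboxylic acid on this same carbon would behave alike. As far as these compounds go, a plain hydrogen there, with the chain of compound 1 kept, is also open.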